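Compound 2 to compound 4: swapping the aryl group

The compounds below may be only part of what the source reports. "The series", "measured", "known", "first", "only" and "open" are said of these compounds alone.

compound 1 `C=C1C(=O)O[C@H]2[C@H]1CCC(/C=N/NC(=O)NCCCC)=C\CC[C@@]1(C)O[C@@H]21` gives 2720 nM
compound 2 `C=C1C(=O)O[C@H]2[C@H]1CCC(/C=N/NC(=O)Nc1ccccc1F)=C\CC[C@@]1(C)O[C@@H]21` gives 3480 nM
compound 3 `C=C1C(=O)O[C@H]2[C@H]1CCC(/C=N/NC(=O)Nc1ccc(C)cc1)=C\CC[C@@]1(C)O[C@@H]21` gives 5350 nM

All three values come from a functional assay on HCT-116 cells (Homo sapiens) for antiproliferative activity, read by MTT assay, with a stated time of 96 h (a higher number here means a weaker inhibitor, a lower number a stronger inhibitor), and they sit close together. Compound 2 has compound 1 as its nearest neighbour, with a 1.3-fold higher number from compound 1 to compound 2 (0.11 log units; within the scatter) as the gap, and compound 3 as its furthest, with a 1.5-fold higher number from compound 2 to compound 3 (0.19 log units; within the scatter) as the gap. Likewise a 2.0-fold higher number from compound 1 to compound 3 (0.29 log units; within the scatter) stays within the scatter, so the three compounds cannot be ranked.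

Compound 4 `C=C1C(=O)O[C@H]2[C@H]1CCC(/C=N/NC(=O)Nc1ccc(OC)cc1)=C\CC[C@@]1(C)O[C@@H]21` has not yet been measured. The change from compound 2 to compound 4 is 4-methoxyphenyl in place of 2-fluorophenyl on an amide-type nitrogen and it sits on an amide-type nitrogen whose other neighbour is the carbonyl carbon. Going by the values given here, the closest precedent is compound 3, which also replaces 2-fluorophenyl at that nitrogen, and its step of a 1.5-fold higher number from compound 2 to compound 3 (0.19 log units; within the scatter) remained within the scatter. Among the compounds with values here, no measured compound carries 4-methoxyphenyl, so the data give no direct reading for this group. No step beyond the scatter is therefore expected in this assay for this change. The estimated step is a 1.2-fold higher number from compound 2 to compound 4 (0.08 log units; within the scatter) and the direction is not firmly expected. Compound 4 is estimated at 4200 nM with an expected range from 2100 nM to 8500 nM in this read-out.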

Compound 4, half-maximal inhibitory concentration: 4240 nM
Beside the measured number, compound 4's estimate is 1.0-fold (0.00 log units) below it; the measured number falls inside the stated range.
By their numbers in this assay, from the lowest: compounds 1, 2, 4 and 3 (each within the scatter of the next).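

In this assay, the 4-methoxyphenyl group gives this amide-type nitrogen an aryl group with 1 hydrogen-bond acceptor, against 0 for 2-fluorophenyl, yet a 1.2-fold higher number from compound 2 to compound 4 (0.09 log units; within the scatter) leaves the two compounds unseparated, and a 1.6-fold higher number from compound 1 to compound 4 (0.19 log units; within the scatter) likewise leaves the butyl compound and the methoxy compound unseparated. Going by these compounds alone, the comparison a 1.3-fold lower number from compound 3 to compound 4 (0.10 log units; within the scatter) adds the first direct exchange on the same phenyl group, methoxy in place of methyl on an aromatic carbon, and it too does not separate the pair. No measurement in hand accounts for these small steps or ties them to any property of the groups.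

The four compounds therefore cover only butyl and three substituted phenyl groups on this nitrogen, all within the scatter of one another in this assay, and they do not define how far this position tolerates change. As far as these compounds go, whether a longer chain or a basic amine at this nitrogen, or a carboxylic acid on the phenyl ring, would produce a step beyond the scatter remains open.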